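Piperazine series: 4-nitrophenyl in place of 2-fluorophenyl

The compounds below may be only part of what the source reports. "The series", "measured", "known", "first", "only" and "open" are said of these compounds alone.

Measured so far:
compound 1, `Nc1nc(N)c2cc(CSC(=S)N3CCN(c4ccccc4)CC3)ccc2n1` — 2950 nM
compound 2, `Nc1nc(N)c2cc(CSC(=S)N3CCN(c4ccccc4F)CC3)ccc2n1` — 4840 nM

Both were read in a functional assay on MCF7 cells (Homo sapiens) for antiproliferative activity, read by MTT assay, with a stated time of 72 h; a lower number here means a stronger inhibitor, a higher number a weaker inhibitor. Among the compounds with values here, the single step with a measurement, a 1.6-fold higher number from compound 1 to compound 2 (0.22 log units; within the scatter), falls inside the scatter, so compound 1 and compound 2 are treated as equivalent. Within the data shown here, compound 2 stands at the higher of the two numbers, with compound 1 as its only neighbour, but that gap is not a difference that the assay can resolve, and no order between them is claimed.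

Compound 3, `Nc1nc(N)c2cc(CSC(=S)N3CCN(c4ccc([N+](=O)[O-])cc4)CC3)ccc2n1`, is the next compound and is still to be measured. It differs from compound 2 as follows: 4-nitrophenyl in place of 2-fluorophenyl on an amine nitrogen in a ring.

Among the measured compounds shown here, no measured step bears directly on this exchange: the one step available replaces a hydrogen with fluoro on the same ring, and that step sits within the scatter. For the measured compounds named here, there is nothing in the two values to support a move in either direction, so the expected step of a 1.2-fold lower number from compound 2 to compound 3 (0.08 log units; within the scatter) is taken as none beyond the scatter, with a wide range to reflect that the larger group has no precedent here. Compound 3 is therefore estimated at 4000 nM, between 1500 nM and 11000 nM.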

Compound 3, half-maximal inhibitory concentration: 1470 nM
Compound 3: middle estimate off by 2.7-fold (0.43 log units), on the high side; the measured number lies below the stated range.
By their numbers in this assay, from the lowest: compounds 3, 1 and 2 (each within the scatter of the next, the first and the last beyond it).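

In this assay, within the data shown here, the exchange of 2-fluorophenyl for 4-nitrophenyl on the amine nitrogen in a ring gives the only step so far that lies beyond the scatter, a 3.3-fold lower number from compound 2 to compound 3 (0.52 log units; beyond the scatter), which shows that this position can register a change, though only a modest one. The comparison with the unsubstituted phenyl group is less clear: a 2.0-fold lower number from compound 1 to compound 3 (0.30 log units; within the scatter), so nitro in place of hydrogen is not resolved on its own, and compound 1 cannot be ordered against either substituted compound; the separation exists only between the two substituted compounds. Nothing in the available data accounts for the step.

Going by these compounds, whether the nitro group is specifically required remains open, as a nitrile, a methoxy group or an amine on the same phenyl ring could read like nitro or like hydrogen. Also open, on these data alone, is whether the step holds when the shared core or the sulfur-containing link to the ring changes, as all three compounds keep both unaltered.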